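Chain extension on a shared positive allosteric modulator core

The compounds below may be only part of what the source reports. "The series", "measured", "known", "first", "only" and "open" are said of these compounds alone.

Compound 1, `CCc1nnc2c(C#N)c(N3CCC(c4ccccc4)CC3)ccn12` — 247%
Compound 2, `CCCc1cnc2c(C#N)c(N3CCC(c4ccccc4)CC3)ccn12` — 254%

Of the compounds shown here, two have been measured in a functional assay on CHO cells for positive allosteric modulation of metabotropic glutamate receptor 2 (Homo sapiens), read by GTPgammaS binding, with a stated time of 30 min; on this read-out lower numbers stand for smaller maximal responses and higher numbers for larger maximal responses. Compound 1 gives 247% and compound 2 gives 254% in this assay. Of the two numbers, that of compound 1 is the lower, but the gap to compound 2 lies within the usual scatter of this kind of measurement, so the two readings do not separate the compounds. Going by the values given here, no pair of measured compounds differs in only one place, so no measured step is available.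

The unmeasured compound 3, `CCCc1nnc2c(C#N)c(N3CCC(c4ccccc4)CC3)ccn12`, differs from compound 1 in one place: methyl in place of hydrogen on a saturated chain carbon, two bonds along the chain from an aromatic carbon. This is a small addition to a short saturated chain and leaves the rest of the molecule untouched. With compound 1 and compound 2 sitting at essentially the same level in this assay, nothing in the available data points to a move in either direction, and compound 3 is therefore expected to show no step beyond the scatter, a number 3 percentage points higher from compound 1 to compound 3 (within the scatter). The estimate for compound 3 in this assay is 250%, within a range from 215% to 285%.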

Compound 3, largest response reached (Emax), in percent of the reference or control that the assay uses: 272%
Beside the measured number, compound 3's estimate is 22 percentage points below it; low and high end bracket the measured number.
By their numbers in this assay, from the lowest: compounds 1 and 2 (each within the scatter of the next); then compound 3.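

In this assay, going by these compounds alone, the change from ethyl to propyl on the shared core produces the first measured step, a number 25 percentage points higher from compound 1 to compound 3 (beyond the scatter), and that step is modest. It shows that this saturated chain carbon, two bonds along the chain from an aromatic carbon, is not silent on this read-out: methyl in place of hydrogen there, a change of one heavy atom with the rest of the molecule untouched, moves the maximal response by more than the usual scatter. Nothing measured here accounts for the rise, so its cause remains unknown.

A single step at a single position leaves open whether the trend continues, levels off or reverses with a longer chain such as butyl or pentyl, and whether a branched group such as isopropyl or a ring such as cyclopropyl would give the same response. It also leaves open how the response would change with a hydroxyl group or an amine at the end of the chain, and whether the step seen with the shared core would recur with other groups elsewhere on the molecule.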